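Replacing the Amide Side Chain of Compound 2 with Pyridin-4-yl

The source may hold more compounds than are shown below. What is called first, only, known or untested is meant among the compounds shown, and "the series" means these compounds.

Compound 1 `COc1cccc(OC)c1C(=O)Nc1c[nH]nc1C(=O)N[C@H]1CC[C@H](O)CC1` and compound 2 `COc1cccc(OC)c1C(=O)Nc1c[nH]nc1C(=O)NCCCN(C)C` share a core and differ only in the group on an amide-type nitrogen. In an ADME assay on MRC5 cells (Homo sapiens) for inhibition, with a stated time of 72 h (a lower number here means that less compound is needed, a higher number that more compound is needed for the effect), compound 1 gives 34000 nM. In this assay, compound 2 gives > 50000 nM, which is a limit of the assay and not a number. Compound 2 therefore has no exact place on the scale and sits at the limit of > 50000 nM in this assay, at which 1 of the 2 values shown sits.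

Compound 3 `COc1cccc(OC)c1C(=O)Nc1c[nH]nc1C(=O)Nc1ccncc1` carries pyridin-4-yl in place of 3-(dimethylamino)propyl on that nitrogen: pyridin-4-yl in place of 3-(dimethylamino)propyl on an amide-type nitrogen. Among the measured compounds shown here, the one measured step that bears on this change is an at least 1.4-fold higher number from compound 1 to compound 2 (0.16 log units; that floor lies within the scatter), which alters the group on the same amide-type nitrogen. That step gives no size beyond the scatter, so it offers no ground for expecting a large move. For the measured compounds named here, compound 1, at 34000 nM, supplies the only exact number, and the expectation for the new compound is anchored on it, with a modest shift toward a lower number or none at all. The expected step is an at least 1.7-fold lower number from compound 2 to compound 3 (0.25 log units; that floor lies within the scatter). For compound 3 the estimated value is 28000 nM, with an expected range of 8000 nM to 50000 nM.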

Compound 3, half-maximal effective concentration: > 50000 nM
Compound 3 ended at the assay's limit (the forecaster's own chance of this, stated with the estimate: 40%); at least 1.7-fold (0.25 log units) between middle value and limit.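

With an aromatic ring on the amide-type nitrogen, compound 3 joins compound 2 at the top of the readable range in this assay, so pyridin-4-yl and the open chain 3-(dimethylamino)propyl cannot be told apart here: the step between these two compounds cannot be read, since each has only a limit of the assay and not a number. Set against the one exact value, pyridin-4-yl in place of 4-hydroxycyclohexyl gives an at least 1.4-fold higher number from compound 1 to compound 3 (0.16 log units; that floor lies within the scatter), so this change, like the earlier one, shows no move beyond the scatter, although its true size may be larger than that floor. Compound 1 is thus the only compound with a measured number, and the other two share one ceiling: the limit of > 50000 nM in this assay, at which 2 of the 3 values shown sit.

As far as these compounds go, how far compound 2 and compound 3 really lie from compound 1 stays open, as does whether any group on this nitrogen lowers the number from the 34000 nM of compound 1. A phenyl ring, a carboxylic acid or a shorter chain ending in an amine might give a readable value in this assay, but the compounds shown do not say on which side of compound 1 it would fall.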